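Swapping benzyl for (pyridin-4-yl)amino on compound 1

The source may hold more compounds than are shown below. What is called first, only, known or untested is meant among the compounds shown, and "the series" means these compounds.

Values so far in an ADME assay on MT4 cells (Homo sapiens) for cytotoxicity, read by MTT assay (a higher number here means that more compound is tolerated, a lower number that less compound is tolerated), are these
Compound 1 `Cc1cc(C)cc(S(=O)(=O)c2c(C(=O)NCc3ccccc3)[nH]c3ccc(Cl)cc23)c1` with 38000 nM as its value
Compound 2 `Cc1cccc(C)c1S(=O)(=O)c1c(C(N)=O)[nH]c2ccc(Cl)cc12` with > 48900 nM as its value
Compound 3 `NC(=O)c1[nH]c2ccc(Cl)cc2c1S(=O)(=O)c1c(Cl)cccc1Cl` with 16000 nM as its value

Compound 1 at 38000 nM holds the higher of the two plain numbers, and compound 3 gives 16000 nM in this comparison. The gap between these two compounds lies beyond the scatter. For compound 2 the entry > 48900 nM is a limit and not a number.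

The next compound is compound 4 `Cc1cc(C)cc(S(=O)(=O)c2c(C(=O)NNc3ccncc3)[nH]c3ccc(Cl)cc23)c1` which keeps the core of compound 1 and changes one group (pyridin-4-yl)amino in place of benzyl on an amide-type nitrogen so that (pyridin-4-yl)amino stands in place of benzyl on an amide-type nitrogen. Going by the values given here, the only measured step is an at least 3.0-fold lower number from compound 2 to compound 3 (0.48 log units; beyond the scatter) and it lies on a sulfonyl sulfur, so it gives no direct measure of a change on the amide-type nitrogen. Among the compounds with values here, it shows only that a single swap elsewhere can shift the number by that much. Within the data shown here, no step at this place has been measured, so the expectation is for no step beyond the scatter in this assay in either direction, with a wide margin. The estimated change is a 1.3-fold lower number from compound 1 to compound 4 (0.10 log units; within the scatter) starting from the measured value of compound 1 at 38000 nM as the anchor. Compound 4 is expected near 30000 nM with an estimated range from 9000 nM to 60000 nM once it is measured.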

Compound 4, half-maximal cytotoxic concentration: 30300 nM
Compound 4: middle estimate off by 1.0-fold (0.00 log units), on the low side, within the range that was stated.
By their numbers in this assay, from the lowest: compounds 3, 4 and 1 (each within the scatter of the next, the first and the last beyond it). At a limit, above all of these: compound 2.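

In this assay, going by these compounds alone, this is the first measured step on the amide-type nitrogen, and it is small: a 1.3-fold lower number from compound 1 to compound 4 (0.10 log units; within the scatter). The swap is not a trivial one on paper, as (pyridin-4-yl)amino brings ring nitrogen, an extra nitrogen on the amide-type nitrogen, and hydrogen-bond donor and acceptors that benzyl lacks, yet the number stays within the scatter. So for this one pair, the position accepts a marked change in atom make-up with no readable shift in cytotoxicity, whereas the earlier swap on a sulfonyl sulfur gave an at least 3.0-fold lower number from compound 2 to compound 3 (0.48 log units; beyond the scatter).

One pair cannot show whether this holds for other groups on the amide-type nitrogen, such as a longer chain like phenethyl, a simple amine or a group carrying a carboxylic acid, and the plain amide appears only with a different group on the sulfonyl sulfur, so it gives no direct comparison. Compound 2 gives only a limit and not a number, which leaves its exact place in the order open: the limit of > 48900 nM in this assay, at which 1 of the 4 values shown sits.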